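The source may hold more compounds than are shown below. What is called first, only, known or untested is meant among the compounds shown, and "the series" means these compounds.

Values in an assay on isolated protein for inhibition of Trypsin II (Bos taurus) (on this read-out higher numbers stand for weaker inhibition and lower numbers for stronger inhibition), for the measured compounds:
- compound 1 `N=C(N)c1cccc(CN2CC[C@H](NS(=O)(=O)c3ccc(-c4ccon4)s3)C2=O)c1`: 1900 nM
- compound 2 `N=C(N)c1ccc(N)c(CN2CC[C@H](NS(=O)(=O)c3ccc(-c4cccnc4)s3)C2=O)c1`: 1500 nM
- compound 3 `N=C(N)c1ccc(N)c(CN2CC[C@H](NS(=O)(=O)c3ccc(-c4ccon4)s3)C2=O)c1`: 1700 nM

Compound 3 stands second highest of the three numbers; the steps are a 1.1-fold lower number from compound 1 to compound 3 (0.05 log units; within the scatter) and a 1.1-fold higher number from compound 2 to compound 3 (0.05 log units; within the scatter), both within the scatter, so the three compounds are indistinguishable on this assay.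

Compound 4 `N=C(N)c1ccc(O)c(CN2CC[C@H](NS(=O)(=O)c3ccc(-c4ccon4)s3)C2=O)c1` differs from compound 3 by hydroxy in place of amino on an aromatic carbon. Among the compounds with values here, the only measured step at that carbon is a 1.1-fold lower number from compound 1 to compound 3 (0.05 log units; within the scatter), which shows that putting an amino group there left this assay unchanged. No hydroxy at that carbon has been measured. On that basis the expected step is no change at the digits printed from compound 3 to compound 4 (within the scatter), nothing beyond the scatter. Compound 4 is estimated at 1700 nM in this assay, expected between 800 nM and 3600 nM.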

Compound 4, inhibition constant: 2900 nM
Estimate against measurement, compound 4: 1.7-fold (0.23 log units) below; low and high end bracket the measured number.
By their numbers in this assay, from the lowest: compounds 2, 3, 1 and 4 (each within the scatter of the next).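

In this assay, hydroxy in place of amino on this aromatic carbon gives a 1.7-fold higher number from compound 3 to compound 4 (0.23 log units; within the scatter) and hydroxy in place of hydrogen gives a 1.5-fold higher number from compound 1 to compound 4 (0.18 log units; within the scatter) on the same read-out. This carbon, ortho to a large group and para to a group of 3 heavy atoms, has now carried hydrogen, amino and hydroxy with no step beyond the scatter. No measurement at hand bears on a cause for these steps.

As far as these compounds go, whether methoxy or a carboxylic acid on this carbon would give a step beyond the scatter stays open. Also open, from the compounds shown here alone, is whether hydroxy there behaves the same with the pyridin-3-yl of compound 2.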